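A few compounds are considered here, and "the series" means these few. Any claim that something is new, unique, unknown or untested is made for them only; others in the source may bear on it.

Compound 1 `O=C(CSc1nc2ccccc2s1)N/N=C/c1ccc(Oc2ccc(Cl)cc2)cc1` and compound 2 `O=C(CSc1nc2ccccc2s1)N/N=C/c1ccc(Oc2ccc3ccccc3c2)cc1` share one core and differ only in the group carried on an oxygen on an aromatic ring. In a physicochemical assay for lipophilicity, in phosphate buffer, measured as octanol-water partition, with a stated time of 24 h (on this read-out higher numbers stand for higher lipophilicity and lower numbers for lower lipophilicity), compound 1 gives 5.6, and in this assay compound 2 gives 5.9. The step of a number 0.30 log units higher from compound 1 to compound 2 (within the scatter) is the only measured one, so compound 2 holds the higher of two numbers, with compound 1 within the scatter of it; no ordering between them can be claimed.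

Compound 3 `Cc1ccc(Oc2ccc(/C=N/NC(=O)CSc3nc4ccccc4s3)cc2)cc1` is not yet measured. Relative to compound 2 the change is 4-methylphenyl in place of naphthalen-2-yl on an oxygen on an aromatic ring. The measured step bears on this only loosely: it shows that exchanging 4-chlorophenyl for naphthalen-2-yl moved the partition coefficient by a number 0.30 log units higher from compound 1 to compound 2 (within the scatter), a small amount. Going from naphthalen-2-yl to 4-methylphenyl removes one aromatic ring, and the expectation is a step of a number 0.60 log units lower from compound 2 to compound 3 (beyond the scatter), a modest fall that is likely to reach beyond the scatter. The estimate for compound 3 in this assay is therefore 5.3, with a plausible range from 4.8 to 5.8.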

Compound 3, partition coefficient: 5.7
Compound 3: middle estimate off by 0.40 log units, on the low side; the range from low to high includes it.
By their numbers in this assay, from the lowest: compounds 1, 3 and 2 (each within the scatter of the next).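

In this assay, 4-methylphenyl on the oxygen has one six-membered aromatic ring of carbon only where naphthalen-2-yl has 2, and this change gives a number 0.20 log units lower from compound 2 to compound 3 (within the scatter), so on these numbers losing that ring does not separate the two compounds. The third compound also brings a comparison the earlier pair could not offer, methyl in place of chloro on an aromatic carbon, which gives a number 0.10 log units higher from compound 1 to compound 3 (within the scatter), and with every step among the three compounds within the scatter, 4-chlorophenyl, naphthalen-2-yl and 4-methylphenyl cannot be put in any order at this position. Nothing available here offers an explanation for how closely these three numbers agree.

All three groups shown on this oxygen carry at least one aromatic ring, so it remains open what a group of another kind, such as an amine, a carboxylic acid or a longer alkyl chain, would give at the same place. It also remains open whether the agreement among these three groups would hold on a different core.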